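Cytotoxicity in kidney cells: a swap at the amino position

The compounds below may be only part of what the source reports. "The series", "measured", "known", "first", "only" and "open" are said of these compounds alone.

Measured so far:
Compound 1 `CCCCNc1nc(N)nc2ccn(CC=C(C)C)c12` gives > 24000 nM in an ADME assay on HEK293 cells (Homo sapiens) for cytotoxicity, read by ATP content, with a stated time of 6 h; on this read-out lower numbers stand for higher toxicity in this test and higher numbers for lower toxicity in this test.
Compound 2 `CCCCNc1nc(N)nc2ccn(Cc3ncc(C)c(OC)c3C)c12` gives > 24000 nM in this assay.
Compound 3 `Cc1nc(CNc2nc(N)nc3ccn(Cc4ccccn4)c23)cs1` gives > 24000 nM in this assay.

Each of these readings is a limit of the assay, not a measured number; for compound 3 the value is a limit as well, so compound 3 cannot be placed against the other two, because all three sit at the limit of > 24000 nM in this assay, at which 3 of the 3 values shown sit. Within these three, no compound can be called more or less toxic than another.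

Compound 4 `Cc1nc(COc2nc(N)nc3ccn(Cc4ccccn4)c23)no1` has not yet been measured. It differs from compound 3 by (5-methyl-1,2,4-oxadiazol-3-yl)methoxy in place of ((2-methyl-1,3-thiazol-4-yl)methyl)amino on an aromatic carbon. Among the measured compounds shown here, with every value shown sitting at the same limit, there is no measured step to lean on, and no change beyond the usual scatter is expected. Compound 4 is therefore expected to give 30000 nM in this assay, within a range of 12000 nM to 100000 nM, and most likely again only a limit. This expectation means a step that the limit leaves unreadable from compound 3 to compound 4.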

Compound 4, half-maximal cytotoxic concentration: > 24000 nM
Compound 4: no number, only a limit; the forecaster's own chance of this, stated with the estimate: 85%; the middle value lies beyond the limit too.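

Compound 3 and compound 4 both give only a limit in this assay, not a number, so no step between them can be read: the limit of > 24000 nM in this assay, at which 4 of the 4 values shown sit.

The compounds shown leave open how far beyond that limit each one lies, and whether any of them differs in toxicity from the others.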